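The source may report more compounds than this note shows. Statements on the series, on what has been measured and on what is new or still open speak of the compounds shown alone.

Measured in a functional assay on NCI-H460 cells (Homo sapiens); on this read-out higher numbers stand for an effect only at larger amounts of compound and lower numbers for an effect already at smaller amounts:
- compound 1 `COc1cc(C2OC(c3ccc(N)c(C)c3)=NN2C(C)=O)cc(OC)c1OC`: 0.059 uM
- compound 2 `CCCCNC(=O)c1c(OC)cc(C2OC(c3ccc(N)c(C)c3)=NN2C(C)=O)cc1OC`: 60 uM
- compound 3 `COc1ccc(C2OC(c3ccc(N(C)C)cc3)=NN2C(C)=O)cc1OC`: 5.1 uM

Compound 2 stands highest of the three, at 60 uM. Compound 4 `COC(=O)c1c(OC)cc(C2OC(c3ccc(N)c(C)c3)=NN2C(C)=O)cc1OC` differs from it by methoxy in place of butylamino on a carbonyl carbon. Going by the values given here, compound 3 offers no single-place step here. Among the compounds with values here, the one measured step that bears on the change is large: a 1000-fold higher number from compound 1 to compound 2 (3.01 log units; beyond the scatter), with butylcarbamoyl in place of methoxy on an aromatic carbon. Given that step, compound 4, which keeps the carbonyl but loses the butylamino, is expected to recover part of it in this assay, moving to a lower number beyond the scatter. The expected change is a 20-fold lower number from compound 2 to compound 4 (1.30 log units; beyond the scatter). For compound 4 the estimate is 3 uM, with an expected range of 0.3 uM to 30 uM.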

Compound 4, concentration for half-maximal effect: 0.51 uM
Estimate against measurement, compound 4: 5.9-fold (0.77 log units) above; the range from low to high includes it.
By their numbers in this assay, from the lowest: compound 1; then compound 4; then compound 3; then compound 2.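

In this assay, most of the loss seen with butylcarbamoyl goes when methoxy replaces butylamino on the carbonyl carbon (a 120-fold lower number from compound 2 to compound 4 (2.07 log units; beyond the scatter)). A carbonyl at this place is thus compatible with a far lower number than the amide alone suggested, yet methoxycarbonyl does not fully match the methoxy of compound 1 (an 8.6-fold higher number from compound 1 to compound 4 (0.94 log units; beyond the scatter)). No measurement shown accounts for either step.

Still open, going by these compounds, is whether the butyl chain or the amide hydrogen drives the difference. Methylamino or plain amino on the same carbonyl carbon would separate the two, and a carboxylic acid there would show how far the ester result extends.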